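Smaller alkyl on the five-membered ring: compound 3

The source may hold more compounds than are shown below. What is called first, only, known or untested is meant among the compounds shown, and "the series" means these compounds.

Within the data shown here, compound 1 `CC(C)n1nc(-c2cc(C(C)(C)C)on2)c2c(N)ncnc21` is the only member of the set with a numerical reading: in an assay on BaF3 cells for inhibition of proto-oncogene tyrosine-protein kinase receptor Ret (Homo sapiens), read by MTT assay, with a stated time of 48 h (on this read-out higher numbers stand for weaker inhibition of growth and lower numbers for stronger inhibition of growth), compound 1 gives 6120 nM. Compound 2 `CCCCCCCn1nc(-c2cc(C3CC3)on2)c2c(N)ncnc21` returns only a limit of the assay, > 10000 nM in this assay. That is the limit of > 10000 nM in this assay, at which 1 of the 2 values shown sits. Compound 1 therefore stands as the single fixed point from which a step can be judged, and it stands at a weak level.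

Compound 3 `CCc1cc(-c2nn(C(C)C)c3ncnc(N)c23)no1` is not yet measured. It differs from compound 1 in one place: ethyl in place of tert-butyl on an aromatic carbon. Among the measured compounds shown here, no measured pair in the set isolates this change, so the step has no precedent here. The step of a 1.5-fold higher number from compound 1 to compound 3 (0.17 log units; within the scatter) is expected to be small, within or just beyond the scatter, leaning towards weaker inhibition. Compound 3 is estimated at 9000 nM, with a range from 3000 nM to 25000 nM, and a fair chance that this assay reports only a limit.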

Compound 3, concentration for 50% growth inhibition: 1560 nM
Compound 3: the middle estimate sits 5.8-fold (0.76 log units) above what was measured; the measured number lies below the stated range.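

The position on the aromatic carbon next to the ring oxygen is not indifferent to the alkyl group it carries: ethyl in place of tert-butyl gives a 3.9-fold lower number from compound 1 to compound 3 (0.59 log units; beyond the scatter) in this assay. Of the two groups, ethyl, with 2 heavy atoms against 4, goes with the stronger inhibition of growth, but a single step sets no trend. No measurement shown gives a cause for this step.

On these data alone, whether the number keeps falling with methyl, or what an amine or a carboxylic acid does at this position, remains open. Compound 2 gives > 10000 nM, which is a limit of the assay, and it differs from compound 1 in more than one place, so no step can be read from it.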